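Enone series: cysteine ester amide cut to hydroxamic acid

The source may hold more compounds than are shown below. What is called first, only, known or untested is meant among the compounds shown, and "the series" means these compounds.

Measured so far in a functional assay on CLL cells (Homo sapiens) for cytotoxicity, read by MTT assay, with a stated time of 48 h; on this read-out lower numbers stand for an effect already at smaller amounts and higher numbers for an effect only at larger amounts of compound:
- compound 1, `C=C(CC)C(=O)c1ccc(OCC(=O)NC(CS)C(=O)OCC)c(Cl)c1Cl`: 4800 nM
- compound 2, `C=C(CC)C(=O)c1ccc(OCC(=O)Nc2ccc(/C=C/C(=O)OCC)cc2)c(Cl)c1Cl`: 1700 nM
- compound 3, `C=C(CC)C(=O)c1ccc(OCC(=O)Nc2ccc(Cl)c(C(=O)O)c2)c(Cl)c1Cl`: 15900 nM

Compound 1 stands second highest of the three numbers. Its nearest neighbour is compound 2, whose number is lower by a margin beyond the scatter; compound 3 lies furthest, with a higher number, again beyond the scatter. No pair among these three differs in only one place, so none of the gaps can be read as a single structural step.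

Compound 4, `C=C(CC)C(=O)c1ccc(OCC(=O)NO)c(Cl)c1Cl`, is the next candidate. It differs from compound 1 at the amide-type nitrogen whose other neighbour is the carbonyl carbon: hydroxy in place of 1-(ethoxycarbonyl)-2-sulfanylethyl on an amide-type nitrogen. The amide is thereby reduced to a hydroxyamino unit, and the whole 1-(ethoxycarbonyl)-2-sulfanylethyl chain is removed.

Nothing in the series tests this kind of truncation, so the size of the step in this assay cannot be anchored to a measured pair. The working expectation is a step of a 1.0-fold higher number from compound 1 to compound 4 (0.02 log units; within the scatter), that is, no change beyond the scatter, with a wide band to either side. On that basis compound 4 is estimated at 5000 nM, in the range 1500 nM to 16000 nM.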

Compound 4, half-maximal effective concentration: 4500 nM
For compound 4 the middle estimate is 1.1-fold (0.05 log units) above the measured one; the measured number falls inside the stated range.
By their numbers in this assay, from the lowest: compound 2; then compounds 4 and 1 (each within the scatter of the next); then compound 3.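

In this assay, exchanging the 1-(ethoxycarbonyl)-2-sulfanylethyl group for hydroxy on the amide-type nitrogen gives a 1.1-fold lower number from compound 1 to compound 4 (0.03 log units; within the scatter). Among the compounds shown here, this is the first comparison that isolates a single place, and it shows that, for this pair, the whole chain with its ester and sulfanyl can be replaced by one hydroxy without a step beyond the scatter, so the read-out does not separate the two groups. Nothing measured on these compounds speaks to the reason for this outcome.

Still open, as far as these compounds go, is whether this holds for other groups on the same nitrogen: a plain amide hydrogen, a methoxy or a short chain such as ethyl would separate the loss of the chain from the gain of the hydroxy. Also open, from the compounds shown here alone, is whether any single part of the chain counts on its own, which a version keeping the ethyl ester without the sulfanyl, or one carrying a free carboxylic acid in place of the ester, would help to settle.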